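The source may hold more compounds than are shown below. What is called first, only, known or untested is meant among the compounds shown, and "the series" means these compounds.

The measured compounds, each with its result in a functional assay on Raji cells (Homo sapiens) for antiproliferative activity, read by MTT assay, with a stated time of 48 h; on this read-out higher numbers stand for weaker inhibition and lower numbers for stronger inhibition:

Compound 1, `CN(C)CCn1c(N)c(-c2nc3ccccc3[nH]2)c2nc(C#N)c(C#N)nc21`, gives 8320 nM.
Compound 2, `CCN(CC)CCn1c(N)c(-c2nc3ccccc3[nH]2)c2nc(C#N)c(C#N)nc21`, gives 8950 nM.
Compound 3, `CN(C)CCCCn1c(-c2c(N)n(C)c3nc(C#N)c(C#N)nc23)nc2ccccc21`, gives 1070 nM.

Compound 1 and compound 2 differ by one change, (diethylamino in place of dimethylamino on a saturated chain carbon, two bonds along the chain from an aromatic nitrogen), and the step it made was a 1.1-fold higher number from compound 1 to compound 2 (0.03 log units; within the scatter). The difference between the core of compound 1 and the core of compound 3 is not broken down here. Compound 4, `CCN(CC)CCCCn1c(-c2c(N)n(C)c3nc(C#N)c(C#N)nc23)nc2ccccc21`, carries the same kind of change against compound 3, (diethylamino in place of dimethylamino on a saturated chain carbon, four bonds along the chain from an aromatic nitrogen), though the place differs: four bonds along the chain from an aromatic nitrogen rather than two. The step from compound 3 to compound 4 is expected to be a 1.1-fold higher number from compound 3 to compound 4 (0.05 log units; within the scatter), resting on the earlier step, which was a 1.1-fold higher number from compound 1 to compound 2 (0.03 log units; within the scatter). Compound 4 is therefore estimated at 1200 nM in this assay, between 600 nM and 2500 nM.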

Compound 4, half-maximal inhibitory concentration: 600 nM
Compound 4: middle estimate off by 2.0-fold (0.30 log units), on the high side; measured number inside the range.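

Putting diethylamino in place of dimethylamino on the core of compound 3 gave, in this assay, a 1.8-fold lower number from compound 3 to compound 4 (0.25 log units; within the scatter). Set beside the earlier step, the change carried from one core to the other with no difference that stands out from the scatter: the same change on two cores in this assay, a 1.1-fold higher number (0.03 log units; within the scatter) from compound 1 to compound 2 and a 1.8-fold lower number (0.25 log units; within the scatter) from compound 3 to compound 4, 1.9-fold (0.28 log units) apart, within the scatter of two such steps This supports reading the change as a small one on these two cores only, and it does not show that it would stay small on any other core.

On these data alone, whether dipropylamino or a primary amine at the chain end would fit the same picture remains open. So does the effect of a longer chain on the core of compound 3.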